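The source may report more compounds than this note shows. Statements on the series, on what has been measured and on what is new or still open speak of the compounds shown alone.

Three compounds have results so far in a functional assay on MRC5 cells (Homo sapiens) for cytotoxicity, read by MTT assay, with a stated time of 48 h (a lower number here means a stronger inhibitor, a higher number a weaker inhibitor), and a fourth is still waiting for its measurement. Compound 1 (`CCOC(=O)C[n+]1cccc(O)c1`) gives > 200000 nM in this assay and this is a limit of the assay, not a number. Compound 2 (`CCCCCCCCCc1ccc(OP(=O)(O)OC[C@H]2O[C@@H](n3cc(F)c(=O)[nH]c3=O)C[C@@H]2OC(=O)c2ccccc2)cc1`) gives 39900 nM in the same test. Compound 3 (`C[n+]1cccc(OP(=O)([O-])OC[C@H]2O[C@@H](n3cc(F)c(=O)[nH]c3=O)C[C@@H]2OC(=O)c2ccccc2)c1`) gives 5750 nM there, which is the lower of the two actual numbers, and its gap to compound 2 lies beyond the usual scatter.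

The change from compound 3 to compound 4 (`CCCCCCCCCC[n+]1cccc(OP(=O)([O-])OC[C@H]2O[C@@H](n3cc(F)c(=O)[nH]c3=O)C[C@@H]2OC(=O)c2ccccc2)c1`) is nonyl in place of hydrogen on a saturated chain carbon bound to an aromatic nitrogen and in words this is nonyl in place of hydrogen on a saturated chain carbon bound to an aromatic nitrogen. Going by the values given here, no measured pair shows what this change does, so the expectation is a judgement with wide margins. A moderate expected step of a 2.3-fold lower number from compound 3 to compound 4 (0.36 log units; beyond the scatter) points toward a lower number, meaning a stronger effect on the cells, though it may stay close to the scatter. For compound 4 the estimated value is 2500 nM with an expected range from 500 nM to 12000 nM in repeated measurements.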

Compound 4, half-maximal inhibitory concentration: 14100 nM
Compound 4: middle estimate off by 5.6-fold (0.75 log units), on the low side; the whole stated range lies below it.
By their numbers in this assay, from the lowest: compound 3; then compound 4; then compound 2. At a limit, above all of these: compound 1.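

Going by these compounds alone, the change from methyl to decyl gives a 2.5-fold higher number from compound 3 to compound 4 (0.39 log units; beyond the scatter) in this assay and so provides the first measured step at this place, a saturated chain carbon bound to an aromatic nitrogen. Adding nonyl in place of hydrogen here takes the number up rather than down, so a long chain at this place does not by itself make a compound more toxic to these cells, although the step is modest. None of the available evidence bears on the reason for this step.

Methyl and decyl alone do not tell how the number behaves at chain lengths in between, so a butyl or hexyl chain could rise, fall or hold steady. On these data alone, a chain ending in a carboxylic acid or an amine also remains open at this place.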